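Cytotoxicity limits across the aryl amide series, compound 4

This account rests on a few compounds, and the source may have more. Where it says the series, first, only, none or still open, it means among the compounds named here.

Compound 1 `CCOC(=O)CCCCCOc1cccc(CN(C(=O)c2ccc(-c3cccc4ccccc34)cc2)C(C)C)c1` carries a naphthalen-1-yl group on the shared core. In an ADME assay on HepG2 cells (Homo sapiens) for cytotoxicity, read by CellTiter-Glo and resazurin assay, with a stated time of 72 h (a lower number here means that less compound is needed, a higher number that more compound is needed for the effect), compound 1 reaches only the assay limit, > 26000 nM. Compound 2 `CCOC(=O)CCCCCOc1cccc(CN(C(=O)c2ccc(-c3cccc(NC(C)=O)c3)cc2)C(C)C)c1` carries 3-acetamidophenyl in that place. In this assay compound 2 likewise stops at the limit, > 26000 nM. Compound 3 `CCOC(=O)CCCCCOc1cccc(CN(C(=O)c2ccc(-c3cccc(OC)c3)cc2)C(C)C)c1` carries 3-methoxyphenyl. In this assay compound 3 is again reported only as a limit, > 21000 nM. Compound 3 therefore stands level with the other two as far as the numbers go: every value is a limit, and the steps a step that the two limits leave unreadable from compound 1 to compound 2, a step that the two limits leave unreadable from compound 1 to compound 3 and a step that the two limits leave unreadable from compound 2 to compound 3 carry no readable size because the values sit at the limit of > 21000 nM in this assay, at which 1 of the 3 values shown sits, or at the limit of > 26000 nM in this assay, at which 2 of the 3 values shown sit.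

Compound 4 `CCOC(=O)CCCCCOc1cccc(CN(C(=O)c2ccc(-c3ccc4c(c3)OCCO4)cc2)C(C)C)c1` differs from compound 3 by 2,3-dihydro-1,4-benzodioxin-6-yl in place of 3-methoxyphenyl on an aromatic carbon. Within the data shown here, no measured step bears directly on this change, and the three steps at hand are unreadable. With all three aryl variants at the limit, compound 4 is expected to remain at or near the limit in this assay, a step that the limit leaves unreadable from compound 3 to compound 4 meaning no change beyond the scatter. Compound 4 is estimated at 26000 nM, within 12000 nM to 60000 nM.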

Compound 4, half-maximal effective concentration: > 24400 nM
Compound 4 gave a limit, no number; the forecaster's own chance of this, stated with the estimate: 85%; the middle value lies beyond the limit too.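

Compound 4 is reported only as a limit in this assay, and its steps from compound 1, compound 2 and compound 3 cannot be read. The compounds shown leave open whether these four aryl groups on the shared core differ at all in this assay.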